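Configuration change at one ring carbon, tolerance at limits

The compounds below may be only part of what the source reports. "The series", "measured", "known", "first", "only" and "open" are said of these compounds alone.

In an ADME assay on ORL8 cells (Homo sapiens) for cytotoxicity, read by WST assay, with a stated time of 72 h (a lower number here means that less compound is tolerated, a higher number that more compound is tolerated), compound 1 (`Nc1ncnc2c1ncn2[C@@H]1O[C@@](F)(CO)[C@H](F)[C@H]1O`) gives > 100000 nM, which is a limit. Compound 2 (`Nc1ncnc2c1ncn2[C@@H]1O[C@](F)(CO)[C@H](F)[C@H]1O`) gives > 200000 nM, also a limit and not a number, so its position can be stated only as that limit. Compound 3 (`Nc1ncnc2c1ncn2[C@@H]1O[C@](F)(CO)[C@@H](F)[C@H]1O`) differs from compound 2 as follows: the two compounds have the same atoms and bonds and differ only in configuration as drawn: 1 of 4 stereo elements differ; a stereocentre at a saturated ring carbon is drawn R in compound 2 and S in compound 3. For the measured compounds named here, the only measured step of this kind is a step that the two limits leave unreadable from compound 1 to compound 2, and it rests on (the fact that compounds 1 and 2 differ only in the configuration as drawn). That step gives no readable size or direction, so no step beyond the scatter is expected, and the expected change is a number no higher from compound 2 to compound 3 (the limit leaves the size open). Compound 3 is estimated at 200000 nM, with an expected range of 70000 nM to 300000 nM.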

Compound 3, half-maximal cytotoxic concentration: 90000 nM
The estimate for compound 3 lay 2.2-fold (0.35 log units) above the measured number, and the stated range covers the measured number.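

The series now has an at least 2.2-fold lower number from compound 2 to compound 3 (0.34 log units; beyond the scatter) in this assay, its first readable step, so the configuration at this saturated ring carbon can shift tolerance. The earlier change between compound 1 and compound 2 could not show this, since its two limits leave that step unreadable. With two stereocentres differing, an at least 1.1-fold lower number from compound 1 to compound 3 (0.04 log units; that floor lies within the scatter) sets only a floor and shows no readable change on its own.

Still open, from the compounds shown here alone, is whether the step at this carbon holds when a methyl group or a chlorine atom replaces either fluorine.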